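From chloro to fluoro: what to expect for compound 3

A few compounds are considered here, and "the series" means these few. Any claim that something is new, unique, unknown or untested is made for them only; others in the source may bear on it.

Two related compounds have been measured so far. In a functional assay on DU-145 cells (Homo sapiens) for inhibition, read by trypan blue exclusion, with a stated time of 72 h (on this read-out higher numbers stand for weaker inhibition and lower numbers for stronger inhibition), compound 2 (`Cn1c(=O)c(S(=O)(=O)c2ccc(Cl)cc2)cc2cnc(Nc3cccc4[nH]ccc34)nc21`) gives 5000 nM and compound 1 (`Cn1c(=O)c(S(=O)(=O)c2ccc(F)cc2)cc2cnc(Nc3ccc4cc[nH]c4c3)nc21`) gives 10000 nM and these two numbers lie within the usual scatter of repeated measurements, which means neither can be called the better inhibitor.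

Compound 3 (`Cn1c(=O)c(S(=O)(=O)c2ccc(F)cc2)cc2cnc(Nc3cccc4[nH]ccc34)nc21`) is compound 2 with one small edit: fluoro in place of chloro on an aromatic carbon, para to a large group, turning 4-chlorophenyl into 4-fluorophenyl (fluoro in place of chloro on an aromatic carbon). Within the data shown here, no measured pair differs in one place only, and the size of such a swap has not been seen directly.

What is expected in this assay is no step beyond the scatter, in either direction. The estimate starts from the value of compound 2 (5000 nM). A move of a 1.2-fold higher number from compound 2 to compound 3 (0.08 log units; within the scatter) is expected, and that stays within the scatter. For compound 3 the estimated value is 6000 nM (expected range 2500 nM to 14000 nM).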

Compound 3, half-maximal inhibitory concentration: 750 nM
Estimate against measurement, compound 3: 8.0-fold (0.90 log units) above; measured number below the stated range.
By their numbers in this assay, from the lowest: compound 3; then compounds 2 and 1 (each within the scatter of the next).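

In this assay, the swap of chloro for fluoro on an aromatic carbon, para to a large group, turns out to matter: it brings a 6.7-fold lower number from compound 2 to compound 3 (0.82 log units; beyond the scatter) even though a single halogen atom is all that changes. The place where the amine nitrogen joins the indole also matters: with the 4-fluorophenyl group kept, 1H-indol-4-yl in place of 1H-indol-6-yl brings a 13-fold lower number from compound 1 to compound 3 (1.12 log units; beyond the scatter) and this gives the first direct view of that change. Compound 3 is therefore the strongest inhibitor of the three in this assay, and going back on either single change, the fluoro or the 1H-indol-4-yl, gives a clearly higher number.

The compounds shown leave open how a hydrogen, a bromo, a methoxy or a nitrile would behave at the same place on the ring, and whether the swap from chloro to fluoro would bring a similar step in a compound carrying 1H-indol-6-yl. Nothing shown here explains why one halogen swap moves the number so far.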